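Sulfoxide to Sulfone on a Benzylamide Scaffold

A few compounds are considered here, and "the series" means these few. Any claim that something is new, unique, unknown or untested is made for them only; others in the source may bear on it.

Of the compounds shown here, three on a shared benzylamide core have been tested in an assay on HeLa cells with Bile acid receptor (Homo sapiens) as the target, read by a luciferase reporter, with a stated time of 24 h; on this read-out lower numbers stand for an effect already at smaller amounts and higher numbers for an effect only at larger amounts of compound. Compound 1 `O=C(O)c1ccc(CNC(=O)c2ccc3ccccc3c2)cc1` gives 1360 nM in this assay. Compound 3 `O=C(O)c1ccc(CNC(=O)c2ccc(-c3ccccc3)cc2)cc1` gives 440 nM. Compound 2 `C[S+]([O-])c1ccc(CNC(=O)c2ccc(C(C)(C)C)cc2)cc1` gives 1300 nM, the second highest of the three numbers; its number and that of compound 1 lie within the scatter of each other, while its gap to compound 3 lies beyond the scatter, compound 3 having the lower number.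

The account now turns to compound 4 `CC(C)(C)c1ccc(C(=O)NCc2ccc(S(C)(=O)=O)cc2)cc1`, which differs from compound 2 in one place: a group of 4 heavy atoms (1 carbon, 2 oxygen, 1 sulfur; no ring) in place of a group of 3 heavy atoms (1 carbon, 1 oxygen, 1 sulfur; no ring), on an aromatic carbon, para to a large group.

For the measured compounds named here, no pair of measured compounds shows this change, so its size is not known. The step is expected to be a 1.3-fold lower number from compound 2 to compound 4 (0.11 log units; within the scatter), not beyond the scatter. For compound 4 the estimate in this assay is 1000 nM, ranging from 400 nM to 2500 nM.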

Compound 4, half-maximal effective concentration: 3800 nM
The estimate for compound 4 lay 3.8-fold (0.58 log units) below the measured number, and the stated range ends below it.
By their numbers in this assay, from the lowest: compound 3; then compounds 2 and 1 (each within the scatter of the next); then compound 4.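

In this assay, methylsulfonyl in place of the sulfoxide on this aromatic carbon, para to a large group, gives a 2.9-fold higher number from compound 2 to compound 4 (0.47 log units; beyond the scatter) and so counts against the sulfone at this position. For the compounds shown here, this is the first pair that differs in one place, and it shows that the number responds to a change confined to the sulfur-bearing group, a response that the earlier compounds, which differ in more than one place, could not isolate. Nothing in the available data accounts for the size or direction of this step.

On these data alone, what remains open is how a methylthio group or a sulfonamide would stand on this same aromatic carbon. As far as these compounds go, it is also open whether the step would carry over to other groups at the far end of the shared core, such as those of compound 1 and compound 3.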